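This account rests on a few compounds, and the source may have more. Where it says the series, first, only, none or still open, it means among the compounds named here.

Working notes on the series. In a functional assay on B16 cells (Mus musculus) for antiproliferative activity, with a stated time of 72 h (on this read-out lower numbers stand for stronger inhibition and higher numbers for weaker inhibition), compound 1 `OC[C@H]1O[C@@H](n2cnc3c(NCc4ccc(F)cc4)ncnc32)[C@H](O)[C@@H]1O` gives "not determined" (no result reported), so no number stands for it. Compound 2 `OC[C@H]1O[C@@H](n2cnc3c(NCc4ccc(Cl)c(Cl)c4)ncnc32)[C@H](O)[C@@H]1O` carries the 3,4-dichlorobenzyl group on the same core. In this assay compound 2 gives > 166000 nM, which is a limit of the assay and not a number. Compound 2 therefore sits at the limit of > 166000 nM in this assay, at which 1 of the 2 values shown sits, and no single value is known for either compound shown so far; no step between measured compounds can be counted.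

Compound 3 `Cc1cccc(CNc2ncnc3c2ncn3[C@@H]2O[C@H](CO)[C@@H](O)[C@H]2O)c1O` is the next entry, differing from compound 2 by 2-hydroxy-3-methylphenyl in place of 3,4-dichlorophenyl on a saturated chain carbon bound to a nitrogen on an aromatic ring. Among the measured compounds shown here, with no measured step to lean on, the step of an at least 1.1-fold lower number from compound 2 to compound 3 (0.04 log units; that floor lies within the scatter) is expected to stay within the scatter rather than move in either direction. Compound 3 is estimated at 150000 nM, within a range from 30000 nM to 400000 nM, and a limit rather than a number is expected as the more likely read-out.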

Compound 3, half-maximal inhibitory concentration: > 166000 nM
Compound 3: a limit, no number; the forecaster's own chance of this, stated with the estimate: 65%; at least 1.1-fold (0.04 log units) between middle value and limit.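

Compound 2 and compound 3 both give a limit of the assay and not a number, so no new step can be read between them: the limit of > 166000 nM in this assay, at which 2 of the 3 values shown sit.

The compounds shown leave open how 3,4-dichlorobenzyl and 2-hydroxy-3-methylbenzyl compare in this assay, and whether any group in this place on the shared core gives a single number there.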